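A few compounds are considered here, and "the series" means these few. Any claim that something is new, unique, unknown or untested is made for them only; others in the source may bear on it.

Measured so far:
- compound 1 `Cc1ccc(OCC(=O)NNC(=O)c2cc3ccccc3oc2=O)c(C(=O)c2cccc(Cl)c2)c1` gives 65400 nM
- compound 2 `Cc1ccc(OCC(=O)NNC(=O)c2cc3ccccc3oc2=O)c(C(=O)c2cccc(Br)c2)c1` gives 68100 nM

In a functional assay on Ehrlich cells (Mus musculus) for cytotoxicity, read by LDH release, with a stated time of 48 h (on this read-out lower numbers stand for stronger inhibition and higher numbers for weaker inhibition), compound 2 stands at 68100 nM and sits level with compound 1 within the scatter. The change to compound 3 `Cc1ccc(OCC(=O)NNC(=O)c2cc3ccccc3oc2=O)c(C(=O)c2ccc(F)cc2)c1` is 4-fluorophenyl in place of 3-bromophenyl on a carbonyl carbon and it puts 4-fluorophenyl in place of 3-bromophenyl on a carbonyl carbon. For the measured compounds named here, the one measured step bearing on this is a 1.0-fold higher number from compound 1 to compound 2 (0.02 log units; within the scatter) and it stayed within the scatter, while no measured compound carries 4-fluorophenyl. With so little evidence, no shift beyond the scatter is expected, in either direction, in this assay and the estimated step is a 1.1-fold lower number from compound 2 to compound 3 (0.05 log units; within the scatter) with wide uncertainty. Compound 3 is expected at 60000 nM with a range from 25000 nM to 130000 nM as the estimate.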

Compound 3, half-maximal inhibitory concentration: 40800 nM
Beside the measured number, compound 3's estimate is 1.5-fold (0.17 log units) above it; the range from low to high includes it.
By their numbers in this assay, from the lowest: compounds 3, 1 and 2 (each within the scatter of the next).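

In this assay, the earlier pair changed only the halogen at one place, whereas compound 3 changes both the halogen and its place on the phenyl ring, and the number still stays within the scatter: a 1.7-fold lower number from compound 2 to compound 3 (0.22 log units; within the scatter) and a 1.6-fold lower number from compound 1 to compound 3 (0.20 log units; within the scatter). All three halogenated phenyl groups on this carbonyl carbon therefore sit level. No measurement shown offers an explanation for this result. As far as these compounds go, it remains open whether an unsubstituted phenyl, a pyridine or an aminophenyl at this position would give a step beyond the scatter.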